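The source may report more compounds than this note shows. Statements on the series, on what has been measured and on what is new or still open speak of the compounds shown alone.

In a functional assay on A549 cells (Homo sapiens) for inhibition, read by CCK-8 assay, with a stated time of 72 h, tested at 8 uM (a higher number here means more inhibition of growth at the concentration tested, a lower number less inhibition of growth), compound 1 `Cc1cc(C)cc(SCc2ccc(/C=C/C(=O)Nc3ccccc3N)cc2)c1` gives 47.3% of inhibition, while compound 2 `CCc1ccc(SCc2ccc(/C=C/C(=O)Nc3ccccc3N)cc2)cc1` gives 68.6% of inhibition, the higher of the two numbers. For the measured compounds named here, the one measured step is a number 21.3 percentage points higher from compound 1 to compound 2 (beyond the scatter) on exchanging 3,5-dimethylphenyl for 4-ethylphenyl on a sulfur. In compound 3 `Nc1ccccc1NC(=O)/C=C/c1ccc(CSc2ccc(C(F)(F)F)cn2)cc1` the same place changes again, with 5-(trifluoromethyl)pyridin-2-yl in place of 4-ethylphenyl on a sulfur as the whole difference from compound 2. The measured step shows that this place can move the number by a modest amount, but it joins two rings of carbon only, so it gives no firm direction for a ring with a hetero atom. With compound 2 at 68.6% as the higher number, a modest fall is expected as likelier than a rise. The estimated step is a number 13.6 percentage points lower from compound 2 to compound 3 (beyond the scatter) with wide uncertainty. Compound 3 is estimated at 55% within an expected range of 30% to 78% of inhibition.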

Compound 3, percent growth inhibition at one concentration: 56.5%
For compound 3 the middle estimate is 1.5 percentage points below the measured one; low and high end bracket the measured number.
By their numbers in this assay, from the lowest: compounds 1 and 3 (each within the scatter of the next); then compound 2.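

In this assay the place on the sulfur now holds a ring with a hetero atom, and the exchange of 4-ethylphenyl for 5-(trifluoromethyl)pyridin-2-yl gives a number 12.1 percentage points lower from compound 2 to compound 3 (beyond the scatter). Against 3,5-dimethylphenyl, the same group gives a number 9.2 percentage points higher from compound 1 to compound 3 (within the scatter), so these two rings cannot be told apart here, while 4-ethylphenyl stands clear of both. No measurement at hand explains these differences between the groups on the sulfur.

On these data alone, the ring nitrogen and the trifluoromethyl enter together, so it remains open which of them goes with the lower number; a plain pyridin-2-yl and a 4-(trifluoromethyl)phenyl on the sulfur would separate the two. Also open, as far as these compounds go, is how this assay would read with a group other than an aromatic ring in this place, such as a cyclohexyl or a longer alkyl chain.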